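Phenylethynyl thiazolopiperidine amides: urea in place of sulfonamide

The source may report more compounds than this note shows. Statements on the series, on what has been measured and on what is new or still open speak of the compounds shown alone.

Measured so far in an assay on HEK293 cells for positive allosteric modulation of metabotropic glutamate receptor 5 (Homo sapiens), read by FLIPR, with a stated time of 1 h; on this read-out lower numbers stand for an effect already at smaller amounts and higher numbers for an effect only at larger amounts of compound:
compound 1 `CCN1CCc2nc(C#Cc3ccccc3)sc2C1`, > 10000 nM
compound 2 `CC(=O)N1CCc2nc(C#Cc3ccccc3)sc2C1`, > 10000 nM
compound 3 `O=S(=O)(C1CC1)N1CCc2nc(C#Cc3ccccc3)sc2C1`, > 10000 nM

Each of these values is a limit of this assay, not a number; compound 3 sits at > 10000 nM and is read only as a limit. The same holds for compound 1 and for compound 2, as the limit of > 10000 nM in this assay, at which 3 of the 3 values shown sit, states. Accordingly the steps a step that the two limits leave unreadable from compound 1 to compound 2, a step that the two limits leave unreadable from compound 1 to compound 3 and a step that the two limits leave unreadable from compound 2 to compound 3 cannot be read in size or direction.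

Compound 4 `O=C(N1CCCCC1)N1CCc2nc(C#Cc3ccccc3)sc2C1` differs from compound 3 by (piperidin-1-yl)carbonyl in place of cyclopropylsulfonyl on an amine nitrogen in a ring. Within the data shown here, no measured step bears on this change, as every step among the measured compounds is hidden by the limit. From compound 3 to compound 4 no readable step is expected, a number no higher from compound 3 to compound 4 (the limit leaves the size open). For compound 4 the value in this assay is estimated at 10000 nM, with a range from 3000 nM to 30000 nM, most likely again reported only as a limit.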

Compound 4, half-maximal effective concentration: 75 nM
For compound 4 the middle estimate is 130-fold (2.12 log units) above the measured one; measured number outside the range, below it.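

In this assay this position can carry a readable value: (piperidin-1-yl)carbonyl in place of cyclopropylsulfonyl gives an at least 130-fold lower number from compound 3 to compound 4 (2.12 log units; beyond the scatter) on the amine nitrogen in a ring. Piperidin-1-yl in place of methyl on a carbonyl carbon gives an at least 130-fold lower number from compound 2 to compound 4 (2.12 log units; beyond the scatter) and (piperidin-1-yl)carbonyl in place of ethyl gives an at least 130-fold lower number from compound 1 to compound 4 (2.12 log units; beyond the scatter) with the rest of the structure unchanged. The steps among compound 1, compound 2 and compound 3 cannot be read, and the sizes of the new steps stay open on one side, since each starts from a limit of the assay: the limit of > 10000 nM in this assay, at which 3 of the 4 values shown sit.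

From the compounds shown here alone, whether the piperidine ring itself is required remains open. A morpholine ring or an open-chain dimethylamino group on the same carbonyl would address this.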